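Triazole hydroxamates: aryl exchange and deacetylase inhibition

The compounds below may be only part of what the source reports. "The series", "measured", "known", "first", "only" and "open" are said of these compounds alone.

Measured in an assay on Sf9 cells for inhibition of protein deacetylase HDAC6 (Homo sapiens), read by fluorescence, with a stated time of 40 min, tested at 100 nM; a higher number here means more inhibition at the concentration tested (going by the name of the read-out), a lower number less inhibition:
compound 1, `Cc1ccc(-c2nc(CNc3ccc(C(=O)NO)cc3)n(-c3ccccc3)n2)cc1`, gives 62.2%
compound 2, `O=C(NO)c1ccc(NCc2nc(-c3ccc(Br)o3)nn2-c2ccccc2)cc1`, gives 55.8%
compound 3, `O=C(NO)c1ccc(NCc2nc(-c3cccc(Cl)c3)nn2-c2ccccc2)cc1`, gives 61.2%

On the numbers shown, compound 2 is not separated from either neighbour: a number 6.4 percentage points lower from compound 1 to compound 2 (within the scatter) and a number 5.4 percentage points higher from compound 2 to compound 3 (within the scatter) both fall within the scatter, so the three compounds read as one group in this assay.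

The unmeasured compound 4, `O=C(NO)c1ccc(NCc2nc(-c3ccc(C(F)(F)F)cc3)nn2-c2ccccc2)cc1`, differs from compound 2 in one place: 4-(trifluoromethyl)phenyl in place of 5-bromofuran-2-yl on an aromatic carbon

Among the measured compounds shown here, two measured steps bear on this change, since each swaps the same aryl group on the same aromatic carbon of the shared core. Going from 4-methylphenyl to 5-bromofuran-2-yl, a number 6.4 percentage points lower from compound 1 to compound 2 (within the scatter), and going from 5-bromofuran-2-yl to 3-chlorophenyl, a number 5.4 percentage points higher from compound 2 to compound 3 (within the scatter), are both within the scatter. Three aryl groups at that carbon therefore give indistinguishable numbers in this assay, and no step beyond the scatter is expected for a fourth aryl group there. Compound 4 is expected to fall near compound 2 and compound 3, with the estimated step of a number 4.2 percentage points higher from compound 2 to compound 4 (within the scatter). The estimate for compound 4 in this assay is 60%, with a range from 46% to 74%.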

Compound 4, a percentage reported as inhibition, at one concentration (the size of the read-out at that concentration, not a potency): 41.6%
Beside the measured number, compound 4's estimate is 18.4 percentage points above it; measured number below the stated range.
By their numbers in this assay, from the lowest: compound 4; then compounds 2, 3 and 1 (each within the scatter of the next).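

In this assay, this position, the aromatic carbon between two ring nitrogen atoms, is not indifferent to the aryl group it carries: 4-(trifluoromethyl)phenyl separates from the earlier aryl groups, with a number 14.2 percentage points lower from compound 2 to compound 4 (beyond the scatter) and a number 19.6 percentage points lower from compound 3 to compound 4 (beyond the scatter), whereas those earlier groups could not be told apart. The closest comparison is trifluoromethyl in place of methyl on the same phenyl group, with a number 20.6 percentage points lower from compound 1 to compound 4 (beyond the scatter), so a change confined to that one substituent is enough to lower the number beyond the scatter, and compound 4 stands lowest of the four. Nothing in the data shown accounts for this drop.

From the compounds shown here alone, it remains open whether the lower number is specific to trifluoromethyl or would also appear with another substituent on that phenyl group, and a methoxy or nitrile group in its place would help to separate these two readings. Going by these compounds, these are also readings at one concentration in a single assay, so how far the step from compound 1 to compound 4 carries over to full potency remains open as well.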